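Piperidinyl in Place of Ethylamino: An Expected Step

This account rests on a few compounds, and the source may have more. Where it says the series, first, only, none or still open, it means among the compounds named here.

Compound 1 `CCNC(=O)/C=C/c1c(/C=C/c2ccc(OC)cc2)cc(OC)cc1OC` is the reference. Among the measured compounds shown here, in a functional assay on MCF7 cells (Homo sapiens) for inhibition, read by MTT assay, with a stated time of 48 h (on this read-out higher numbers stand for weaker inhibition and lower numbers for stronger inhibition), compound 1 gives 7060 nM, the highest of the two numbers measured so far. For the measured compounds named here, its nearest neighbour is compound 2 `COc1ccc(/C=C/c2cc(OC)cc(OC)c2/C=C/C(=O)NC(C)C)cc1`, which in this assay gives 2560 nM; the single change between them, methyl in place of hydrogen on a saturated chain carbon bound to an amide-type nitrogen and a saturated chain carbon, produced a 2.8-fold lower number from compound 1 to compound 2 (0.44 log units; beyond the scatter). The unmeasured compound 3 `COc1ccc(/C=C/c2cc(OC)cc(OC)c2/C=C/C(=O)N2CCCC(C)C2)cc1` differs from compound 1 as follows: 3-methylpiperidin-1-yl in place of ethylamino on a carbonyl carbon. Going by the values given here, the only measured step that bears on this change is the one from compound 1 to compound 2, a modest gain, and the present change at the same amide-type nitrogen is larger in scope, so the comparison is loose. The step expected in this assay is a 2.0-fold lower number from compound 1 to compound 3 (0.30 log units; within the scatter). Compound 3 is accordingly estimated at 3500 nM, with a range from 1200 nM to 10000 nM.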

Compound 3, half-maximal inhibitory concentration: 11900 nM
Compound 3: middle estimate off by 3.4-fold (0.53 log units), on the low side, outside the stated range (above it).
By their numbers in this assay, from the lowest: compound 2; then compounds 1 and 3 (each within the scatter of the next).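

In this assay, 3-methylpiperidin-1-yl in place of ethylamino on the carbonyl carbon gives a 1.7-fold higher number from compound 1 to compound 3 (0.23 log units; within the scatter) and so cannot be told apart from the ethylamino group, even though the entering group carries a six-membered ring and no hydrogen-bond donor. Against the isopropylamino group at the same place, the picture differs, with a 4.6-fold higher number from compound 2 to compound 3 (0.67 log units; beyond the scatter) showing that the gain seen with isopropylamino does not extend to this ring group. Nothing in the data shown explains this outcome.

On these data alone, what plain piperidin-1-yl, without the methyl, would give on this carbonyl carbon remains open. So does whether a longer chain such as n-butylamino would follow isopropylamino, and whether dimethylamino, which lacks the amide hydrogen but has no ring, would follow 3-methylpiperidin-1-yl.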